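Fluorine Added to a Weakly Antiproliferative Pair

The source may hold more compounds than are shown below. What is called first, only, known or untested is meant among the compounds shown, and "the series" means these compounds.

Compound 1 `Cc1noc(-c2cc3ccccc3[nH]2)n1`: 11800 nM
Compound 2 `c1ccc(-c2noc(-c3cc4ccccc4[nH]3)n2)cc1`: 12000 nM

In a functional assay on COLO 320 cells (Homo sapiens) for antiproliferative activity, read by WST assay, with a stated time of 72 h (a lower number here means a stronger inhibitor, a higher number a weaker inhibitor), compound 1 gives 11800 nM and compound 2 gives 12000 nM. Compound 2 sits beside compound 1 rather than apart from it, as the step of a 1.0-fold higher number from compound 1 to compound 2 (0.01 log units; within the scatter) shows. Compound 3 `Fc1ccc2[nH]c(-c3nc(-c4ccccc4)no3)cc2c1` differs from compound 2 by fluoro in place of hydrogen on an aromatic carbon. Among the measured compounds shown here, no measured pair carries this change; the only known step exchanged phenyl for methyl and stayed within the scatter, so nothing points to movement. The step from compound 2 to compound 3 is expected to be no change at the digits printed from compound 2 to compound 3 (within the scatter), none beyond the scatter. Compound 3 is therefore estimated at 12000 nM, within 5000 nM to 30000 nM.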

Compound 3, half-maximal inhibitory concentration: 10800 nM
Estimate against measurement, compound 3: 1.1-fold (0.05 log units) above, and the stated range covers the measured number.
By their numbers in this assay, from the lowest: compounds 3, 1 and 2 (each within the scatter of the next).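

In this assay, fluoro in place of hydrogen gives a 1.1-fold lower number from compound 2 to compound 3 (0.05 log units; within the scatter). This position, on the six-membered aromatic ring of carbon only, therefore accepts a single fluorine with no shift beyond the scatter, whereas the earlier step between compound 1 and compound 2 showed this only for a change elsewhere on the molecule. Nothing available explains this result. Going by these compounds, whether a larger group at this position, such as an amine or a carboxylic acid, would shift the number remains open. So does whether fluoro would behave the same on another carbon of this ring.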